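The compounds below may be only part of what the source reports. "The series", "measured", "known", "first", "only" and "open" are said of these compounds alone.

Measured so far in a functional assay on the whole organism (strain albino CF-1) with Mus musculus as the target, in the maximal electroshock model, with a stated time of 4 h; on this read-out lower numbers stand for an effect already at smaller amounts and higher numbers for an effect only at larger amounts of compound:
- compound 1 `CCCOc1cccc(/C=N/n2c(-c3ccccc3)nc3ccccc3c2=O)c1`: 30 mg/kg
- compound 2 `C=CCCOc1cccc(/C=N/n2c(-c3ccccc3)nc3ccccc3c2=O)c1`: 100 mg/kg
- compound 3 `CCCCOc1cccc(/C=N/n2c(-c3ccccc3)nc3ccccc3c2=O)c1`: 100 mg/kg

Compound 3 stands level with compound 2, the two together giving the highest numbers of the three in this assay; the step of no change at the digits printed from compound 2 to compound 3 (within the scatter) lies within the scatter. Against compound 1 the step of a 3.3-fold higher number from compound 1 to compound 3 (0.52 log units; beyond the scatter) is the only one beyond the scatter, with the parallel a 3.3-fold higher number from compound 1 to compound 2 (0.52 log units; beyond the scatter).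

Compound 4 `COc1cccc(/C=N/n2c(-c3ccccc3)nc3ccccc3c2=O)c1` differs from compound 3 as follows: hydrogen in place of propyl on a saturated chain carbon bound to an oxygen on an aromatic ring. Within the data shown here, no measured pair covers this change directly. The nearest step in kind is the reverse of a 3.3-fold higher number from compound 1 to compound 3 (0.52 log units; beyond the scatter), which shows that taking one carbon off the butyl chain of compound 3 brings the number down to that of compound 1. Whether removing two more carbons moves the number further, or back up, is not shown by any pair here; compound 2 and compound 3 show only that a change at the chain end, within the same length, leaves the number unchanged.

The expectation for compound 4 is therefore a step of a 3.3-fold lower number from compound 3 to compound 4 (0.52 log units; beyond the scatter), with the estimate for compound 4 in this assay put at 30 mg/kg, between 10 mg/kg and 100 mg/kg.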

Compound 4, minimum effective dose: 100 mg/kg
The estimate for compound 4 lay 3.3-fold (0.52 log units) below the measured number; the range from low to high includes it.
By their numbers in this assay, from the lowest: compound 1; then compounds 2, 3 and 4 (each within the scatter of the next).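

In this assay, cutting butoxy to methoxy gives no change at the digits printed from compound 3 to compound 4 (within the scatter) and removing allyl gives no change at the digits printed from compound 2 to compound 4 (within the scatter), so the shortest chain shown reads the same as the chains of compound 2 and compound 3. Removing ethyl gives a 3.3-fold higher number from compound 1 to compound 4 (0.52 log units; beyond the scatter), the same direction as the steps that lengthen the chain of compound 1. The number therefore does not run one way with chain length across these four compounds, and compound 1 alone stands apart, a single value on which the whole difference rests.

Nothing measured here accounts for the position of compound 1. Open, from the compounds shown here alone, is how the number responds at this oxygen to a longer chain such as hexyl, or to a chain ending in an amine or a carboxylic acid.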